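A few compounds are considered here, and "the series" means these few. Any claim that something is new, unique, unknown or untested is made for them only; others in the source may bear on it.

Three measured compounds share one core. In an assay on cells for inhibition of MAP kinase-interacting serine/threonine-protein kinase 1 (Homo sapiens), read by mobility shift assay, with stated times of 10 min and 60 min, in the presence of a further agent that is not named here (on this read-out lower numbers stand for stronger inhibition and higher numbers for weaker inhibition), compound 1 `CCOc1cc(-c2cccnc2)ccc1C(N)=O` gives 2200 nM. In this assay compound 2 `NC(=O)c1ccc(-c2cccnc2)cc1Cl` gives 11000 nM, and compound 3 `NC(=O)c1ccc(-c2cccnc2)cc1` gives 8800 nM. Compound 3 thus stands second highest of the three numbers; the step of a 1.3-fold lower number from compound 2 to compound 3 (0.10 log units; within the scatter) is within the scatter, whereas the step of a 4.0-fold higher number from compound 1 to compound 3 (0.60 log units; beyond the scatter) lies beyond it. The unmeasured compound 4 `COc1cc(-c2cccnc2)ccc1C(N)=O` differs from compound 3 by methoxy in place of hydrogen on an aromatic carbon. The measured step that bears most directly on this is a 4.0-fold higher number from compound 1 to compound 3 (0.60 log units; beyond the scatter), the loss of ethoxy from that same carbon; the step of a 5.0-fold higher number from compound 1 to compound 2 (0.70 log units; beyond the scatter) points the same way, in that ethoxy gave the lowest number of the three. Since methoxy resembles ethoxy, a lower number is expected in this assay for compound 4, of a size somewhat short of the full reverse of the ethoxy step. The expected step is a 2.9-fold lower number from compound 3 to compound 4 (0.47 log units; beyond the scatter). Compound 4 is therefore estimated at 3000 nM, with a range from 1200 nM to 8000 nM.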

Compound 4, half-maximal inhibitory concentration: 2800 nM
Beside the measured number, compound 4's estimate is 1.1-fold (0.03 log units) above it; measured number inside the range.
By their numbers in this assay, from the lowest: compounds 1 and 4 (each within the scatter of the next); then compounds 3 and 2 (each within the scatter of the next).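

In this assay, methoxy on the aromatic carbon ortho to a carbamoyl group brings a 3.1-fold lower number from compound 3 to compound 4 (0.50 log units; beyond the scatter) and so shows that the shorter chain also carries the change first seen with ethoxy at this position. Methoxy in place of chloro on this carbon gives a 3.9-fold lower number from compound 2 to compound 4 (0.59 log units; beyond the scatter) and separates the two groups clearly, whereas the shortening of ethoxy to methoxy gives a 1.3-fold higher number from compound 1 to compound 4 (0.10 log units; within the scatter) and does not tell the two apart. The two groups joined through oxygen therefore stand together here, apart from chloro and hydrogen.

No evidence on why methoxy and ethoxy differ from chloro and hydrogen at this carbon is available. On these data alone, it stays open whether a longer chain such as propoxy, or an amine on the same carbon, would give numbers like those of methoxy and ethoxy.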